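This account rests on a few compounds, and the source may have more. Where it says the series, first, only, none or still open, it means among the compounds named here.

Of the compounds shown here, three sharing one core have been measured in a functional assay on K562 cells (Homo sapiens) for antiproliferative activity, read by MTT assay, with a stated time of 48 h; on this read-out higher numbers stand for weaker inhibition and lower numbers for stronger inhibition. Compound 2 `COc1ccc(CN2C(=O)C(=O)c3cc(-c4ccc(OC)cc4)ccc32)cc1` gives 30 nM, the lowest of the three numbers. Compound 1 `COc1ccc(-c2ccc3c(c2)C(=O)C(=O)N3Cc2ccc(Br)cc2)cc1` gives 100 nM, and compound 3 `COc1ccc(-c2ccc3c(c2)C(=O)C(=O)N3Cc2ccc3ccccc3c2)cc1` gives 400 nM. The move a 3.3-fold lower number from compound 1 to compound 2 (0.52 log units; beyond the scatter) and the move a 13-fold higher number from compound 2 to compound 3 (1.12 log units; beyond the scatter) both lie beyond the scatter, so compound 2 stands as the strongest inhibitor among the three.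

Compound 4 `COc1ccc(CN2C(=O)C(=O)c3cc(-c4ccc5ccccc5c4)ccc32)cc1` is not yet measured. It differs from compound 2 in one place: naphthalen-2-yl in place of 4-methoxyphenyl on an aromatic carbon. The entering group, naphthalen-2-yl, has already entered twice, though at a different place, on a saturated chain carbon bound to an amide-type nitrogen in a ring. There it brought a 4.0-fold higher number from compound 1 to compound 3 (0.60 log units; beyond the scatter) and a 13-fold higher number from compound 2 to compound 3 (1.12 log units; beyond the scatter), one modest and one large weakening. Within the data shown here, no measured pair shows this change on an aromatic carbon, so how far those moves carry over is uncertain. Therefore a modest weakening is expected, namely a 4.0-fold higher number from compound 2 to compound 4 (0.60 log units; beyond the scatter). Compound 4 is estimated to give 120 nM in this assay, within a range from 40 nM to 400 nM.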

Compound 4, half-maximal inhibitory concentration: 340 nM
Compound 4: middle estimate off by 2.8-fold (0.45 log units), on the low side, and the stated range covers the measured number.
By their numbers in this assay, from the lowest: compound 2; then compound 1; then compounds 4 and 3 (each within the scatter of the next).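

In this assay, naphthalen-2-yl in place of 4-methoxyphenyl on this aromatic carbon gives a large loss, an 11-fold higher number from compound 2 to compound 4 (1.05 log units; beyond the scatter), the first measured sign that this position is sensitive to the group it carries. The same swap on the saturated chain carbon gave a 13-fold higher number from compound 2 to compound 3 (1.12 log units; beyond the scatter), also large, so in compound 2 the 4-methoxyphenyl group outperforms naphthalen-2-yl at both places tested. Nothing available explains why the number rises at either place.

The swap removes the methoxy group and adds a second aromatic ring in one step, so these compounds cannot show which of the two matters. Also open, from the compounds shown here alone, is how a plain phenyl, a 4-hydroxyphenyl or a pyridin-3-yl group would behave on this aromatic carbon.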